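The compounds below may be only part of what the source reports. "The series", "measured", "known", "first", "only" and "open" are said of these compounds alone.

Working notes on the series.

Compound 1 `CC(C)C[C@H](N)c1cc(Cl)ccc1N1CCN(C(=O)[C@H]2CCO[C@@H]2c2ccc(Cl)cc2)CC1` gives 280 nM in an assay on HEK293 cells for displacement of a labelled ligand from Melanocortin receptor 4 (Homo sapiens); on this read-out higher numbers stand for weaker inhibition and lower numbers for stronger inhibition. Compound 2 `CC(C)C[C@H](NC(=O)CCN)c1cc(C(F)(F)F)ccc1N1CCN(C(=O)C2C(=O)OCC2c2ccc(Cl)cc2)CC1` gives 180 nM in this assay. Compound 3 `CC(C)[C@H](NC(=O)CCN(C)C)c1cccc(F)c1N1CCN(C(=O)[C@H]2COC[C@@H]2c2ccc(Cl)cc2)CC1` gives 30 nM in this assay, the lowest of the three numbers; the gap from compound 3 to compound 2 and the gap from compound 3 to compound 1 both lie beyond the scatter, so compound 3 stands as the strongest binder measured so far. The three compounds differ in several places at once, so no single change can be read off from the measured pairs.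

Compound 4 `CC(C)[C@H](NC(=O)CCN(C)C)c1cccc(F)c1N1CCN(C(=O)[C@@H]2COC[C@@H]2c2ccc(Cl)cc2)CC1` is the next step from compound 3. The difference: the two compounds have the same atoms and bonds and differ only in configuration as drawn: 1 of 3 stereo elements differ; a stereocentre at a saturated ring carbon is drawn R in compound 3 and S in compound 4. Among the compounds with values here, no measured pair in this set differs only in configuration, so there is nothing in the numbers to calibrate this step against. The expectation is that the step from compound 3 to compound 4 is a 4.0-fold higher number from compound 3 to compound 4 (0.60 log units; beyond the scatter) in this assay, toward a higher number. Within the data shown here, the data hold no step of this kind, so the size of that expected step is left open. For compound 4 the estimate in this assay is 120 nM, with a range from 30 nM to 600 nM.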

Compound 4, inhibition constant: 28 nM
Estimate against measurement, compound 4: 4.3-fold (0.63 log units) above; the measured number lies below the stated range.
By their numbers in this assay, from the lowest: compounds 4 and 3 (each within the scatter of the next); then compounds 2 and 1 (each within the scatter of the next).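

Turning the stereocentre at a saturated ring carbon from R to S gives a 1.1-fold lower number from compound 3 to compound 4 (0.03 log units; within the scatter) in this assay, so the two configurations at this position cannot be told apart on this read-out. Within the data shown here, this is the first pair that isolates a single place, whereas the earlier compounds differed in several places at once and allowed no such reading. The step can be laid on this one stereocentre alone, with no other change to account for, because of a single feature of the pair: the fact that compounds 3 and 4 differ only in the configuration as drawn

The compounds shown leave open whether the other two stereo elements of compound 3 are equally silent in this assay, since neither has been varied on its own in any pair here, and whether the same holds with a different amide side chain on the shared core. Among these compounds, also open is whether a hydroxyl group or a methyl group on this saturated ring carbon would leave the number near the one compound 3 gives, 30 nM.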